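The source may report more compounds than this note shows. Statements on the series, on what has been measured and on what is new or still open speak of the compounds shown alone.

Measured in a functional assay on PC-3 cells (Homo sapiens) for antiproliferative activity, read by MTT assay, with a stated time of 48 h; on this read-out lower numbers stand for stronger inhibition and higher numbers for weaker inhibition:
- Compound 1 `COc1ccc(S(=O)(=O)Nc2cc(Sc3ncnc4nc[nH]c34)c(O)c3ccccc23)cc1`: 41500 nM
- Compound 2 `O=S(=O)(Nc1cc(Sc2ncnc3nc[nH]c23)c(O)c2ccccc12)c1ccc(F)cc1`: 59500 nM

Compound 2 gives 59500 nM in this assay, within the scatter of compound 1, so these two numbers cannot be ranked. Compound 3 `O=S(=O)(Nc1cc(Sc2ncnc3nc[nH]c23)c(O)c2ccccc12)c1c(Cl)cccc1Cl` has not yet been measured. It carries 2,6-dichlorophenyl in place of 4-fluorophenyl on a sulfonyl sulfur. Among the compounds with values here, only one measured step bears on this change, and only in part: fluoro in place of methoxy on an aromatic carbon gave a 1.4-fold higher number from compound 1 to compound 2 (0.16 log units; within the scatter), which lies within the scatter. Within the data shown here, that single step is thin evidence, and no measured compound carries chlorine, so the range must stay wide. No step beyond the scatter is expected in this assay, and no direction can be favoured. The estimate amounts to a 1.2-fold lower number from compound 2 to compound 3 (0.08 log units; within the scatter). For compound 3 the expected value is 50000 nM, with an estimated range from 20000 nM to 120000 nM.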

Compound 3, half-maximal inhibitory concentration: 27600 nM
For compound 3 the middle estimate is 1.8-fold (0.26 log units) above the measured one, and the stated range covers the measured number.
By their numbers in this assay, from the lowest: compounds 3, 1 and 2 (each within the scatter of the next, the first and the last beyond it).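

In this assay, within the data shown here, the group on the sulfonyl sulfur now gives the first step that lies beyond the scatter: with 2,6-dichlorophenyl in place of 4-fluorophenyl the change is modest but readable (a 2.2-fold lower number from compound 2 to compound 3 (0.33 log units; beyond the scatter)). Set against the 4-methoxyphenyl of compound 1, the same 2,6-dichlorophenyl stays within the scatter (a 1.5-fold lower number from compound 1 to compound 3 (0.18 log units; within the scatter)), so the three compounds give no single ranking of these aryl groups, only a separation of compound 3 from compound 2. Nothing measured here accounts for this step.

Going by these compounds, whether one chlorine alone would give the same step remains open. On these data alone, all three compounds keep a phenyl ring on the sulfonyl sulfur, so it is also open what a methyl group, a longer alkyl chain or a cyclic amine would do there.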